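Replacing Hydroxy with Methylsulfanyl at the Shared Core

The compounds below may be only part of what the source reports. "The series", "measured", "known", "first", "only" and "open" are said of these compounds alone.

Compound 3 `Oc1ncnc2c1ncn2Cc1ccccc1` is one of three analogues tested in a functional assay on the whole organism for inhibition, with Rattus norvegicus as the target, in the maximal electroshock model, at a dose of 25 mg/kg by the intraperitoneal route; on this read-out higher numbers stand for more inhibition at the one dose given (going by the name of the read-out) and lower numbers for less inhibition. Compound 1 `c1ccc(Cn2cnc3cncnc32)cc1` gives 33%, compound 2 `CC(C)N(C)c1ncnc2c1ncn2Cc1ccccc1` gives 17%, and compound 3 gives 17%, level with compound 2 and together with it the lowest of the three. Putting a group onto compound 1 lowered the read-out in both cases: a number 16 percentage points lower from compound 1 to compound 2 (beyond the scatter) and a number 16 percentage points lower from compound 1 to compound 3 (beyond the scatter). Compound 4 `CSc1ncnc2c1ncn2Cc1ccccc1` differs from compound 3 by methylsulfanyl in place of hydroxy on an aromatic carbon. Among the measured compounds shown here, no measured step covers this exchange; the only swap of one substituent for another on that aromatic carbon, no change at the digits printed from compound 2 to compound 3 (within the scatter), stayed within the scatter. The step is therefore expected to be a number 3 percentage points higher from compound 3 to compound 4 (within the scatter), not beyond the scatter. Compound 4 is expected to give about 20%, within 5% to 40%.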

Compound 4, a percentage reported as inhibition, in the whole organism at one dose (the size of the read-out at that dose, not a potency): 30%
For compound 4 the middle estimate is 10 percentage points below the measured one; low and high end bracket the measured number.
By their numbers in this assay, from the lowest: compounds 2 and 3 (each within the scatter of the next); then compounds 4 and 1 (each within the scatter of the next).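

Methylsulfanyl is the first group on this aromatic carbon to stand apart from another substituent, with a number 13 percentage points higher from compound 3 to compound 4 (beyond the scatter) against hydroxy and a number 13 percentage points higher from compound 2 to compound 4 (beyond the scatter) against isopropyl(methyl)amino. A substituent here therefore need not lower the read-out: replacing hydrogen with methylsulfanyl gives a number 3 percentage points lower from compound 1 to compound 4 (within the scatter) and stays level with the unsubstituted compound. No available evidence accounts for the difference between these groups.

The compounds shown leave open whether the sulfur or the methyl matters here, and whether methoxy, ethylsulfanyl or a primary amine on this carbon would keep the read-out at this level.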